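This account rests on a few compounds, and the source may have more. Where it says the series, first, only, none or still open, it means among the compounds named here.

Compound 1 `CC(C)CCC1C(=O)Nc2ccc(Nc3ccc(Cl)cc3)cc21` gives 2000 nM
Compound 2 `CC(C)CCC1(O)C(=O)Nc2ccc(Nc3ccc(F)cc3)cc21` gives 5700 nM
Compound 3 `CCCCCC1(O)C(=O)Nc2ccc(Nc3ccc(Cl)cc3)cc21` gives 1900 nM

In a functional assay on A549 cells (Homo sapiens) for antiproliferative activity, read by MTT assay, with a stated time of 48 h (a higher number here means a weaker inhibitor, a lower number a stronger inhibitor), compound 3 stands level with compound 1, within the scatter, while compound 2 lies beyond the scatter from compound 3, with the higher number and so the weaker inhibition.

Compound 4 `CC(C)CCC1(O)C(=O)Nc2ccc(Nc3ccc(Cl)cc3)cc21` has not yet been measured. It has the same atoms as compound 3, joined differently: isopropyl in place of propyl on a saturated chain carbon, two bonds along the chain from a saturated ring carbon and so isopropyl sits in place of propyl on a saturated chain carbon, two bonds along the chain from a saturated ring carbon. The same difference reads as pentyl to isopentyl.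

Among the compounds with values here, no measured pair shows this change alone. With the isopentyl chain, compound 1 gives 2000 nM and this stays within the scatter of compound 3. Compound 2 goes against any simple reading: it gives 5700 nM with the isopentyl chain, but it carries fluorine where compound 4 carries chlorine.

No step beyond the scatter is expected in this assay and the estimate is a 1.2-fold higher number from compound 3 to compound 4 (0.06 log units; within the scatter) towards a slightly higher number. For compound 4 the expected value is 2200 nM with an estimated range from 1100 nM to 4500 nM overall.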

Compound 4, half-maximal inhibitory concentration: 2700 nM
The estimate for compound 4 lay 1.2-fold (0.09 log units) below the measured number; the range from low to high includes it.
By their numbers in this assay, from the lowest: compounds 3, 1 and 4 (each within the scatter of the next); then compound 2.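

In this assay, the isopropyl in place of propyl on a saturated chain carbon, two bonds along the chain from a saturated ring carbon, gives a 1.4-fold higher number from compound 3 to compound 4 (0.15 log units; within the scatter) and so can now be read alone, with no step beyond the scatter. Hydroxy in place of hydrogen on a saturated ring carbon, with the isopentyl chain and chloro kept, gives a 1.4-fold higher number from compound 1 to compound 4 (0.13 log units; within the scatter) and also stays within the scatter. Chloro in place of fluoro on an aromatic carbon gives a 2.1-fold lower number from compound 2 to compound 4 (0.32 log units; beyond the scatter) and is the only one of the three changes that goes beyond the scatter, though only modestly.

The compounds shown leave open how a bromo or a methoxy group on that aromatic carbon would compare with chloro, and whether a hexyl chain or a chain ending in an amine would stay level with the pentyl and isopentyl chains. They also leave open whether the chloro and hydroxy steps would hold with the pentyl chain, as each is seen only once, with the isopentyl chain.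

Nothing given here accounts for these steps.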